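The source may hold more compounds than are shown below. What is called first, only, known or untested is meant among the compounds shown, and "the series" means these compounds.

Measured in a functional assay on RS4-11 cells (Homo sapiens) for inhibition, read by CCK-8 assay, with a stated time of 72 h; a higher number here means a weaker inhibitor, a lower number a stronger inhibitor:
compound 1 `CC1(C)CCC(CN2CCN(c3ccc(C(=O)NS(=O)(=O)c4ccc(NCC5CCOCC5)c([N+](=O)[O-])c4)c(Oc4cnc5[nH]ccc5c4)c3)CC2)=C(c2ccccc2C(F)(F)F)C1`: 18 nM
compound 2 `CC1(C)CCC(CN2CCN(c3ccc(C(=O)NS(=O)(=O)c4ccc(NCC5CCOCC5)c([N+](=O)[O-])c4)c(Oc4cnc5[nH]ccc5c4)c3)CC2)=C(c2ccc(C(F)(F)F)c(Cl)c2)C1`: 81 nM
compound 3 `CCN(CC)CCCNc1ccc(S(=O)(=O)NC(=O)c2ccc(N3CCN(CC4=C(c5ccc(C(F)(F)F)cc5)CC(C)(C)CC4)CC3)cc2Oc2cnc3[nH]ccc3c2)cc1[N+](=O)[O-]`: 3 nM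

Of these three, compound 3 has the lowest number, 3 nM, which makes it the strongest inhibitor here. Its gaps to compound 1 and compound 2 both lie beyond the scatter.

Compound 4 `CC1(C)CCC(CN2CCN(c3ccc(C(=O)NS(=O)(=O)c4ccc(OCC5CCOCC5)c([N+](=O)[O-])c4)c(Oc4cnc5[nH]ccc5c4)c3)CC2)=C(c2ccc(C(F)(F)F)cc2)C1` comes from compound 3 by one swap: (oxan-4-yl)methoxy in place of (3-(diethylamino)propyl)amino on an aromatic carbon. The swap sits on an aromatic carbon, ortho to a nitro group and para to a large group.

Going by the values given here, no measured step covers this place. Among the compounds with values here, the only one, a 4.5-fold higher number from compound 1 to compound 2 (0.65 log units; beyond the scatter), acts on a double-bonded ring carbon instead, so it shows only that a single swap can move the number beyond the scatter.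

Closer guidance comes from compound 1, at 18 nM, and compound 2, at 81 nM. Both carry the oxan-4-yl ring at the changing place, though joined through nitrogen rather than oxygen, and both also differ from compound 3 in the group on the double-bonded ring carbon. The guide is therefore loose, but it points upward.

The expected step is a 12-fold higher number from compound 3 to compound 4 (1.07 log units; beyond the scatter), a clear rise towards weaker inhibition in this assay. For compound 4 the estimated value is 35 nM, with an expected range from 10 nM to 150 nM.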

Compound 4, half-maximal inhibitory concentration: 5.9 nM
Beside the measured number, compound 4's estimate is 5.9-fold (0.77 log units) above it; the whole stated range lies above it.
By their numbers in this assay, from the lowest: compounds 3 and 4 (each within the scatter of the next); then compound 1; then compound 2.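

At this place, on an aromatic carbon ortho to a nitro group, two very different groups can stand with no reading beyond the scatter: in this assay the swap of (3-(diethylamino)propyl)amino for (oxan-4-yl)methoxy gives a 2.0-fold higher number from compound 3 to compound 4 (0.29 log units; within the scatter) and leaves the two compounds level within that scatter. The group that leaves is an open chain with two nitrogens and one hydrogen-bond donor, while the group that enters carries a six-membered non-aromatic ring, two oxygens and no donor, so in this pair neither the nitrogens nor the donor is needed to keep the number in the low nanomolar range seen for compound 3. Nothing shown here accounts for this outcome.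

Because the atom joined to the aromatic carbon and the rest of the group change together in this single step, its two parts cannot be told apart, and a (3-(diethylamino)propyl)oxy group, which would keep the chain and change only the joining atom, would be needed to separate them. On these data alone, it also remains open how a carboxylic acid at the end of the chain, or a longer chain, would read at this place.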